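The source may hold more compounds than are shown below. What is called first, only, known or untested is meant among the compounds shown, and "the series" means these compounds.

Compound 1, `C/C(=N\NC(=O)c1cccc(S(=O)(=O)N2CCOCC2)c1)c1ccccc1O`, gives 5450 nM in a functional assay on ECa-109 cells for antiproliferative activity against ECa-109 cell line (Homo sapiens), read by MTT assay, with a stated time of 72 h; on this read-out higher numbers stand for weaker inhibition and lower numbers for stronger inhibition. Compound 2, `C/C(=N\NC(=O)c1cccc(S(=O)(=O)N2CCOCC2)c1)c1cc(F)ccc1O`, gives 3270 nM in this assay.

For the measured compounds named here, on these two numbers compound 2 has the lowest value, and its nearest neighbour is compound 1; the only measured step, a 1.7-fold lower number from compound 1 to compound 2 (0.22 log units; within the scatter), lies within the scatter, so the two compounds cannot be told apart on this read-out. Compound 3, `C/C(=N\NC(=O)c1cccc(S(=O)(=O)N2CCOCC2)c1)c1cccc(N)c1O`, is the next compound to be tested. Its change from compound 2 is 3-amino-2-hydroxyphenyl in place of 5-fluoro-2-hydroxyphenyl on a carbon with a double bond to nitrogen. Going by the values given here, the single measured step bears on this only in part: it exchanged hydrogen for fluoro, whereas here the fluoro leaves and an amino group arrives as part of the 3-amino-2-hydroxyphenyl, a kind of change for which no measured step exists. Among the compounds with values here, since the one step that is known, a 1.7-fold lower number from compound 1 to compound 2 (0.22 log units; within the scatter), stayed within the scatter, no step beyond the scatter is expected in this assay for compound 3. Compound 3 is therefore estimated at 5000 nM, within 1600 nM to 16000 nM. The step this estimate implies is a 1.5-fold higher number from compound 2 to compound 3 (0.18 log units; within the scatter), expected to remain within the scatter.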

Compound 3, half-maximal inhibitory concentration: 5060 nM
Compound 3: middle estimate off by 1.0-fold (0.01 log units), on the low side; the range from low to high includes it.
By their numbers in this assay, from the lowest: compounds 2, 3 and 1 (each within the scatter of the next).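

For the compounds shown here, the amino group is the first group on this aromatic ring to bring in a new heteroatom type, and the counts rise from 1 to 2 hydrogen-bond donors and from 1 to 2 hydrogen-bond acceptors in the exchange of 5-fluoro-2-hydroxyphenyl for 3-amino-2-hydroxyphenyl on a carbon with a double bond to nitrogen, yet this assay records only a 1.5-fold higher number from compound 2 to compound 3 (0.19 log units; within the scatter). The arrival of the amino group, read on its own, gives a 1.1-fold lower number from compound 1 to compound 3 (0.03 log units; within the scatter), so neither this group nor the earlier fluoro separates its compound from the unsubstituted one on this read-out, and all three compounds remain indistinguishable. No measurement is available that could account for this result.

Going by these compounds, whether any group on this ring can produce a step beyond the scatter remains open, for instance a carboxylic acid, a nitro group or a dimethylamino group in place of the amino or the fluoro. On these data alone, it is equally open what a methoxy group in place of the hydroxy would do, or whether a longer chain in place of the methyl on the carbon with a double bond to nitrogen would change the number.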